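The compounds below may be only part of what the source reports. "The series", "measured", "known", "first", "only" and "open" are said of these compounds alone.

For the measured compounds named here, in a physicochemical assay for lipophilicity, measured as octanol-water partition, at pH 7.4 (on this read-out higher numbers stand for higher lipophilicity and lower numbers for lower lipophilicity), compound 2 `COc1ccc(Cn2c(=O)[nH]c3c(N)nc(C(F)(F)F)cc32)cn1` gives 2.8, the higher of the two numbers measured so far. Going by the values given here, the only other measured compound is compound 1 `Cc1ccc(Cn2c(=O)[nH]c3c(N)nc(C(F)(F)F)cc32)nn1`, which gives 1.1. Among the compounds with values here, the single measured step between them, a number 1.70 log units higher from compound 1 to compound 2 (beyond the scatter), is large and lies beyond the scatter. It shows that exchanging the ring group on the saturated chain carbon can move this read-out a long way while the shared core stays the same.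

Compound 3 `Nc1ccc(Cn2c(=O)[nH]c3c(N)nc(C(F)(F)F)cc32)cn1` keeps that core and the pyridine ring of compound 2, and changes one group: amino in place of methoxy on an aromatic carbon. Within the data shown here, no measured step covers this exact exchange, so the guidance is only indirect. Among the measured compounds shown here, the one step available, a number 1.70 log units higher from compound 1 to compound 2 (beyond the scatter), replaced a whole ring group, whereas this exchange alters a single group on the ring, so a smaller move is expected. In this assay, the expected change, estimated as a number 1.00 log units lower from compound 2 to compound 3 (beyond the scatter), is a downward one that should still clear the scatter. Compound 3 is expected to give about 1.8, with an estimated range from 1.3 to 2.3.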

Compound 3, distribution coefficient: 1.5
Estimate against measurement, compound 3: 0.30 log units above, and the stated range covers the measured number.
By their numbers in this assay, from the lowest: compound 1; then compound 3; then compound 2.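

In this assay, the exchange of amino for methoxy gives a number 1.30 log units lower from compound 2 to compound 3 (beyond the scatter) and is large, so altering one small group on this ring carbon, para to a large group, can shift the read-out strongly; the earlier step had involved swapping a whole ring group. The other new step, a number 0.40 log units higher from compound 1 to compound 3 (beyond the scatter), is modest but beyond the scatter, so on this read-out the 6-aminopyridin-3-yl group lies much nearer to the 6-methylpyridazin-3-yl group than the 6-methoxypyridin-3-yl group does. These numbers record the size and direction of the shifts, but nothing available here accounts for them.

The compounds shown leave open where a hydroxyl, a methyl or a dimethylamino group on this same ring carbon would fall, and such groups could show whether this large fall is particular to the amino group or is shared by other replacements for methoxy. As far as these compounds go, it also remains open whether an amino group in place of the methyl on the 6-methylpyridazin-3-yl ring would move the number in the same direction and by a similar amount.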